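Replacing the indolyl group on the amide carbonyl

A few compounds are considered here, and "the series" means these few. Any claim that something is new, unique, unknown or untested is made for them only; others in the source may bear on it.

Of the compounds shown here, three built on one shared core have been measured. Compound 1 `O=C(c1ccccc1)N1CCc2nc(COc3cccc(F)c3)oc2C1` gives 73% in a functional assay on HEK293 cells for positive allosteric modulation of metabotropic glutamate receptor 5 (Homo sapiens), read by calcium flux; on this read-out lower numbers stand for smaller maximal responses and higher numbers for larger maximal responses. Compound 2 `O=C(c1c[nH]c2ccccc12)N1CCc2nc(COc3ccccc3)oc2C1` gives 71% in this assay, the second highest of the three numbers; its nearest neighbour is compound 3 `Cn1cc(C(=O)N2CCc3nc(COc4ccccc4)oc3C2)c2ccccc21`, which gives 70%, and the furthest is compound 1, whose number is higher, though every gap among the three lies within the scatter. For the measured compounds named here, the only step between measured compounds that differ in one place is a number 1 percentage points lower from compound 2 to compound 3 (within the scatter), a methyl in place of hydrogen on an aromatic nitrogen.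

Compound 4 `O=C(c1n[nH]c2cccnc12)N1CCc2nc(COc3ccccc3)oc2C1` has not yet been measured. It differs from compound 2 in one place: a group of 9 heavy atoms (6 carbon, 3 nitrogen; one five-membered aromatic ring with 2 hetero atoms, one six-membered aromatic ring with 1 hetero atom) in place of a group of 9 heavy atoms (8 carbon, 1 nitrogen; one five-membered aromatic ring with 1 hetero atom, one six-membered aromatic ring of carbon only), on a carbonyl carbon. Going by the values given here, no measured step covers a change of this kind; the one known step, a number 1 percentage points lower from compound 2 to compound 3 (within the scatter), altered the same group in a smaller way and stayed within the scatter. With nothing pointing either way, a step no larger than the scatter is expected, a number 1 percentage points lower from compound 2 to compound 4 (within the scatter). Compound 4 is therefore estimated to give 70% in this assay, between 55% and 85%.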

Compound 4, largest response reached (reported as percent of maximum), in percent of the reference or control that the assay uses: 29%
For compound 4 the middle estimate is 41 percentage points above the measured one, outside the stated range (below it).
By their numbers in this assay, from the lowest: compound 4; then compounds 3, 2 and 1 (each within the scatter of the next).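

The group on the carbonyl carbon clearly matters: in this assay the new group gives a number 42 percentage points lower from compound 2 to compound 4 (beyond the scatter), whereas the methyl on the aromatic nitrogen gave only a number 1 percentage points lower from compound 2 to compound 3 (within the scatter). The change keeps 9 heavy atoms and 1 hydrogen-bond donor, so those counts alone do not predict the response at this position; what differs is the nitrogen count in the two rings and the rise from 0 to 2 hydrogen-bond acceptors. Nothing available here bears on why the response drops.

Since the nitrogens in the five-membered and six-membered rings differ together, the compounds shown cannot assign the loss to either ring. A 1H-indazol-3-yl group, whose six-membered ring is carbon only, would separate the two, and a pyrrolyl group would test whether both rings are needed at all.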